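The source may report more compounds than this note shows. Statements on the series, on what has been measured and on what is new or still open speak of the compounds shown alone.

Compounds measured:
Compound 1, `O=C(/C=C/c1ccccc1Cl)Nc1ccc2ncnc(Nc3cccc(Cl)c3)c2c1`, in a functional assay on B16-F10 cells (Mus musculus) for inhibition, read by MTT assay, with a stated time of 48 h (on this read-out higher numbers stand for weaker inhibition and lower numbers for stronger inhibition), compound 1 gives 1.74 ug/mL.
Compound 2, `Cc1ccc(/C=C/C(=O)Nc2ccc3ncnc(Nc4cccc(Cl)c4)c3c2)cc1`, in this assay compound 2 gives 2.02 ug/mL.

Among the compounds with values here, compound 2 stands highest of the two numbers so far, but its only neighbour is compound 1, and the step of a 1.2-fold higher number from compound 1 to compound 2 (0.06 log units; within the scatter) lies within the scatter, so the two cannot be ordered. Compound 3, `O=C(/C=C/c1cccc2ccccc12)Nc1ccc2ncnc(Nc3cccc(Cl)c3)c2c1`, has not yet been measured. It differs from compound 2 in one place: naphthalen-1-yl in place of 4-methylphenyl on a double-bonded chain carbon bound to a double-bonded chain carbon. Within the data shown here, the single measured step that bears on this change is the exchange of one aryl group for another on the same chain carbon, the step of a 1.2-fold higher number from compound 1 to compound 2 (0.06 log units; within the scatter), which was within the scatter. On that evidence alone, an exchange of the aryl group at this position has so far left the number essentially unchanged, and the same is expected here: no step beyond the scatter in this assay in either direction. The expected step of a 1.1-fold higher number from compound 2 to compound 3 (0.04 log units; within the scatter) is therefore estimated to lie within the scatter. Among the measured compounds shown here, for compound 3 the estimate in this assay is 2.2 ug/mL, with a range from 1 ug/mL to 5 ug/mL, the range kept wide since only one comparable step exists.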

Compound 3, half-maximal inhibitory concentration: 0.671 ug/mL
Compound 3: the middle estimate sits 3.3-fold (0.52 log units) above what was measured, and the stated range ends above it.
By their numbers in this assay, from the lowest: compound 3; then compounds 1 and 2 (each within the scatter of the next).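

In this assay, the aryl group on a double-bonded chain carbon bound to a double-bonded chain carbon now proves able to move the number, which the exchange between compound 1 and compound 2 did not show. Naphthalen-1-yl in place of 4-methylphenyl gives a step beyond the scatter (a 3.0-fold lower number from compound 2 to compound 3 (0.48 log units; beyond the scatter)), and naphthalen-1-yl in place of 2-chlorophenyl gives another (a 2.6-fold lower number from compound 1 to compound 3 (0.41 log units; beyond the scatter)), so the result does not hang on one reference compound, though both steps are modest. No measurement on hand accounts for this difference, which comes with a change from one six-membered aromatic ring of carbon only to 2 such rings.

With a single two-ring group among these compounds, it remains open whether the lower number goes with the second ring itself or with this particular naphthalen-1-yl group, and a quinolinyl or biphenyl group at the same place would separate those readings. From the compounds shown here alone, it also remains open whether a saturated cyclohexyl group, or a longer chain between the double bond and the ring, would keep the lower number.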